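The source may hold more compounds than are shown below. What is called first, only, known or untested is meant among the compounds shown, and "the series" means these compounds.

Compound 1 `COc1ccc(F)cc1-c1ccnc2[nH]c(C3=CCN([C@H]4CC[C@H](C(=O)O)CC4)CC3)cc12` gives 400 ng.h/mL 
Compound 2 `COc1ccc(F)cc1-c1c(F)cnc2[nH]c(C3=CCN([C@H]4CC[C@H](C(=O)O)CC4)CC3)cc12` gives 450 ng.h/mL 

Among the compounds with values here, in an ADME assay on the whole organism (Rattus norvegicus) for pharmacokinetics, at a dose of 1 mg/kg by the oral route (on this read-out lower numbers stand for lower exposure and higher numbers for higher exposure at the dose given), compound 2 stands at 450 ng.h/mL and lies within the scatter of its only measured neighbour, compound 1 at 400 ng.h/mL in the same test. Within the data shown here, compound 3 `COc1ccc(F)cc1-c1c(F)cnc2[nH]c(C3=CCN([C@H]4CC[C@H](CC(=O)O)CC4)CC3)cc12` has carboxymethyl in place of carboxy on a saturated ring carbon as its sole difference from compound 2. Among the measured compounds shown here, the one measured step, a 1.1-fold higher number from compound 1 to compound 2 (0.05 log units; within the scatter) for fluoro in place of hydrogen on an aromatic carbon, is a different change and bears on this one only weakly. For the measured compounds named here, no measured step touches the carboxy group, so the data give no direction. No step beyond the scatter is therefore expected, though with wide uncertainty. The estimate amounts to a 1.3-fold lower number from compound 2 to compound 3 (0.11 log units; within the scatter) as the expected outcome. In this assay the expected number for compound 3 is 350 ng.h/mL with an estimated range from 100 ng.h/mL to 1200 ng.h/mL at this dose.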

Compound 3, area under the concentration-time curve: 140 ng.h/mL
Compound 3: the middle estimate sits 2.5-fold (0.40 log units) above what was measured, and the stated range covers the measured number.
By their numbers in this assay, from the lowest: compound 3; then compounds 1 and 2 (each within the scatter of the next).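

Changing 4-carboxycyclohexyl to 4-(carboxymethyl)cyclohexyl gives the first step beyond the scatter among these compounds: this assay shows a 3.2-fold lower number from compound 2 to compound 3 (0.51 log units; beyond the scatter) for this change. This saturated ring carbon is therefore a place where a change of a single added carbon is enough to move the oral exposure number, whereas the earlier fluoro for hydrogen change on an aromatic carbon gave a 1.1-fold higher number from compound 1 to compound 2 (0.05 log units; within the scatter) and so showed no such movement. No measurement shown accounts for the lower number.

The compounds shown leave open whether the number keeps falling with a longer chain such as carboxyethyl, and whether an amide or a primary amine on that same carbon would behave differently. They also leave open whether this step would hold on the core of compound 1, without the added fluoro.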